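Ester variation on the shared core: compound 4

This account rests on a few compounds, and the source may have more. Where it says the series, first, only, none or still open, it means among the compounds named here.

Compound 1 `C=C1C(=O)O[C@H]2CC3=C[C@H](C/C(C)=C/[C@@H](OC(=O)c4ccc([N+](=O)[O-])cc4)[C@H]12)OC3=O` carries a 4-nitrophenyl group on the ester carbonyl carbon of the shared core. In a functional assay on A549 cells (Homo sapiens) for cytotoxicity, read by MTT assay, with a stated time of 48 h (on this read-out higher numbers stand for weaker inhibition and lower numbers for stronger inhibition), compound 1 gives only a limit, > 10000 nM, so it stands at no number of its own. Compound 2 `C=C1C(=O)O[C@H]2CC3=C[C@H](C/C(C)=C/[C@@H](OC(=O)CCCCC)[C@H]12)OC3=O` also gives only a limit in this assay, > 10000 nM. Compound 3 `C=C1C(=O)O[C@H]2CC3=C[C@H](C/C(C)=C/[C@@H](OC(=O)CC4CCCCC4)[C@H]12)OC3=O` gives 6900 nM in this assay. The step that the two limits leave unreadable from compound 1 to compound 2 is thus unreadable, the step of an at least 1.4-fold lower number from compound 1 to compound 3 (0.16 log units; that floor lies within the scatter) has a floor within the scatter, and an at least 1.4-fold lower number from compound 2 to compound 3 (0.16 log units; that floor lies within the scatter) likewise. The series is dominated by the limit of > 10000 nM in this assay, at which 2 of the 3 values shown sit.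

Compound 4 `C=C1C(=O)O[C@H]2CC3=C[C@H](C/C(C)=C/[C@@H](OC(=O)C45CCC(C)(C(=O)O4)C5(C)C)[C@H]12)OC3=O` differs from compound 1 by a group of 11 heavy atoms (9 carbon, 2 oxygen; one five-membered non-aromatic ring of carbon only, one five-membered non-aromatic ring with 1 hetero atom) in place of a group of 9 heavy atoms (6 carbon, 1 nitrogen, 2 oxygen; one six-membered aromatic ring of carbon only), on a carbonyl carbon. Going by the values given here, the only readable comparison for a saturated group in place of the 4-nitrophenyl on the carbonyl carbon is an at least 1.4-fold lower number from compound 1 to compound 3 (0.16 log units; that floor lies within the scatter), whose floor lies within the scatter; no step beyond the scatter is therefore expected from compound 1 to compound 4, and a limit remains likely. Compound 4 is expected to give 9000 nM in this assay, within 4000 nM to 30000 nM. The expected step is an at least 1.1-fold lower number from compound 1 to compound 4 (0.04 log units; that floor lies within the scatter).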

Compound 4, half-maximal inhibitory concentration: 3400 nM
Compound 4: middle estimate off by 2.6-fold (0.42 log units), on the high side, outside the stated range (below it).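

In this assay, going by these compounds alone, changing the group on this carbonyl carbon now gives steps beyond the scatter, which the earlier compounds did not show: an at least 2.9-fold lower number from compound 1 to compound 4 (0.46 log units; beyond the scatter), and an at least 2.9-fold lower number from compound 2 to compound 4 (0.46 log units; beyond the scatter). Within the data shown here, the comparison with the only other exact value gives a 2.0-fold lower number from compound 3 to compound 4 (0.31 log units; beyond the scatter), so the read-out also separates the two saturated ring-bearing groups at this position, not only these groups from 4-nitrophenyl or pentyl. The steps from compound 1 and compound 2 remain floors rather than sizes because both of those compounds sit at a limit: the limit of > 10000 nM in this assay, at which 2 of the 4 values shown sit.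

Whether the five-membered ring with 1 hetero atom or the five-membered ring of carbon only carries the step stays open, and no compound shown separates the two. From the compounds shown here alone, it is also open how a group carrying an amine or a carboxylic acid would read on this carbonyl carbon.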